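The source may hold more compounds than are shown below. What is called first, only, known or untested is meant among the compounds shown, and "the series" means these compounds.

Working notes on the series. The three measured compounds share one core. Compound 1 `COc1ccc(/C=C2\CN(C)C/C(=C\c3ccccc3F)C2=O)cc1` gives 15400 nM in a functional assay on THP-1 cells (Homo sapiens) for cytotoxicity, read by MTT assay, with a stated time of 24 h; on this read-out higher numbers stand for weaker inhibition and lower numbers for stronger inhibition. Compound 2 `COc1cc(/C=C2\CN(C)C/C(=C\c3ccccc3F)C2=O)cc(OC)c1` gives 1170 nM in the same assay, and compound 3 `COc1cc(/C=C2\CN(C)C/C(=C\c3ccccc3F)C2=O)cc(OC)c1OC` gives 640 nM. Compound 2 thus stands second highest of the three numbers: its nearest neighbour is compound 3, reached by a 1.8-fold lower number from compound 2 to compound 3 (0.26 log units; within the scatter), which stays within the scatter; its furthest is compound 1, whose number is clearly higher than that of compound 2, a gap beyond the scatter.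

Compound 4 `COc1cc(/C=C2\CN(C)C/C(=C\c3ccc(Br)cc3)C2=O)cc(OC)c1` has not been measured in this assay. Against compound 2 the change is 4-bromophenyl in place of 2-fluorophenyl on a double-bonded chain carbon bound to a double-bonded ring carbon. Within the data shown here, the only measured step in this set, a 1.8-fold lower number from compound 2 to compound 3 (0.26 log units; within the scatter), adds a methoxy on an aromatic carbon of a different part of the molecule and does not touch the 2-fluorophenyl, so nothing measured speaks directly to swapping that group for 4-bromophenyl. Among the measured compounds shown here, with no step of the same kind available, the expectation for compound 4 is a number close to that of compound 2, with no step beyond the scatter, but with wide uncertainty because the change has no precedent here.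

Compound 4 is therefore estimated at 1200 nM, with an expected range of 400 nM to 3600 nM, which means an expected step of a 1.0-fold higher number from compound 2 to compound 4 (0.01 log units; within the scatter).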

Compound 4, half-maximal inhibitory concentration: 4270 nM
For compound 4 the middle estimate is 3.6-fold (0.55 log units) below the measured one; measured number outside the range, above it.
By their numbers in this assay, from the lowest: compounds 3 and 2 (each within the scatter of the next); then compound 4; then compound 1.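

Among these compounds, this change gives the first look at the aromatic group on the double-bonded chain carbon, and in this assay it gives a 3.6-fold higher number from compound 2 to compound 4 (0.56 log units; beyond the scatter), whereas the only earlier one-place step, a 1.8-fold lower number from compound 2 to compound 3 (0.26 log units; within the scatter), stays within the scatter. The read-out therefore responds to a change at this place, with the direction toward a higher number, meaning weaker inhibition, for this one pair only. The 2-fluorophenyl and 4-bromophenyl groups match in heavy-atom count, and neither carries a hydrogen-bond donor, a hydrogen-bond acceptor or a net charge, so these counts do not separate them, and no measurement at hand accounts for the step.

The compounds shown leave open whether the step goes with bromine replacing fluorine or with the different position of the halogen on the ring, as both differences arrive together in this single pair. Also open, going by these compounds, are how an amine or a carboxylic acid in place of the halogen would read, and whether adding a methoxy, as in the step to compound 3, would give a similar result alongside 4-bromophenyl.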